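The compounds below may be only part of what the source reports. "The series", "measured", "known", "first", "only" and "open" are said of these compounds alone.

Measured in an ADME assay on MT4 cells (Homo sapiens) for cytotoxicity, with a stated time of 5 days; a higher number here means that more compound is tolerated, a lower number that less compound is tolerated:
- Compound 1 `CC(C)(C)C#Cc1cc(N(C(=O)[C@H]2CC[C@H](C)CC2)[C@H]2CC[C@H](OC3COC3)CC2)c(C(=O)O)s1`: > 20000 nM, a limit.
- Compound 2 `CC(C)(C)C#Cc1cc(N(C(=O)[C@H]2CC[C@H](C)CC2)[C@H]2C[C@@H](Oc3cccnc3)C2)c(C(=O)O)s1`: > 20000 nM, a limit.
- Compound 3 `CC(C)(C)C#Cc1cc(N(C(=O)[C@H]2CC[C@H](C)CC2)[C@H]2CC[C@H](OC3CCOC3)CC2)c(C(=O)O)s1`: > 20000 nM, a limit.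

Within the data shown here, compound 3 has only this limit and no number. It stands where the whole set stands: the limit of > 20000 nM in this assay, at which 3 of the 3 values shown sit.

Compound 4 `CON=C1CCC(N(c2cc(C#CC(C)(C)C)sc2C(=O)O)C(=O)[C@H]2CC[C@H](C)CC2)CC1` keeps the shared core and changes the group on the amide-type nitrogen: a group of 9 heavy atoms (7 carbon, 1 nitrogen, 1 oxygen; one six-membered non-aromatic ring of carbon only) in place of a group of 12 heavy atoms (10 carbon, 2 oxygen; one five-membered non-aromatic ring with 1 hetero atom, one six-membered non-aromatic ring of carbon only), on an amide-type nitrogen.

Among the measured compounds shown here, three measured steps bear on this. The change at the same place gives a step that the two limits leave unreadable from compound 2 to compound 3, and also a step that the two limits leave unreadable from compound 1 to compound 2. The change on the oxygen on a saturated carbon gives a step that the two limits leave unreadable from compound 1 to compound 3. None of them supplies a size, so the expectation rests on the shared limit of compound 1, compound 2 and compound 3 in this assay.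

No step beyond the scatter is expected, and another limit is the likely report. The expected step is a step that the limit leaves unreadable from compound 3 to compound 4.

For compound 4 the estimate is 22000 nM, with an expected range of 10000 nM to 40000 nM.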

Compound 4, half-maximal cytotoxic concentration: > 20000 nM
Compound 4 gave a limit, no number (the forecaster's own chance of this, stated with the estimate: 85%); the middle value lies beyond the limit too.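

In this assay compound 4 gives > 20000 nM, a limit and not a number. The steps from compound 1, compound 2 and compound 3 to compound 4 cannot be read, as the whole set stands at one limit: the limit of > 20000 nM in this assay, at which 4 of the 4 values shown sit.

The compounds shown leave open whether the group on the amide-type nitrogen changes the tolerated concentration at all.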